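The source may report more compounds than this note shows. Statements on the series, on what has been measured and on what is new or still open speak of the compounds shown alone.

Compound 1 `CC(C)(C)c1cc2nn(-c3ccccc3)c(N)c2c(=O)[nH]1` gives 15% in an assay on isolated protein for inhibition of serine/threonine-protein kinase D2 (Homo sapiens), read by mobility shift assay, tested at 30 uM; on this read-out lower numbers stand for less inhibition and higher numbers for more inhibition at the one concentration tested (going by the name of the read-out).
Compound 2 `Nc1c2c(=O)[nH]c(-c3ccccn3)cc2nn1-c1ccccc1` gives 15% in this assay.
Compound 3 `COc1ccccc1-c1cc2nn(-c3ccccc3)c(N)c2c(=O)[nH]1` gives 20% in this assay.

On the numbers shown, compound 3 stands level with the other two: a number 5 percentage points higher from compound 1 to compound 3 (within the scatter) and a number 5 percentage points higher from compound 2 to compound 3 (within the scatter), so the three compounds cannot be told apart in this assay. The next compound, compound 4 `COc1ccc(-c2cc3nn(-c4ccccc4)c(N)c3c(=O)[nH]2)cc1`, differs from compound 3 in a single place: 4-methoxyphenyl in place of 2-methoxyphenyl on an aromatic carbon.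

Among the measured compounds shown here, three measured steps bear on this position, each exchanging the group on the same aromatic carbon. no change at the digits printed from compound 1 to compound 2 (within the scatter), a number 5 percentage points higher from compound 1 to compound 3 (within the scatter) and a number 5 percentage points higher from compound 2 to compound 3 (within the scatter) were all small, and none moved the inhibition beyond the scatter, even though the groups exchanged were quite unlike one another. For the measured compounds named here, no measured step moves a methoxy group within the phenyl ring itself, so the change from compound 3 to compound 4 is not directly covered. Given that the groups tried so far gave no step beyond the scatter, the expected change in this assay is no change at the digits printed from compound 3 to compound 4 (within the scatter), that is none beyond the scatter. Compound 4 is therefore estimated at 20%, within 5% to 35%.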

Compound 4, a percentage reported as inhibition, at one concentration (the size of the read-out at that concentration, not a potency): 28%
The estimate for compound 4 lay 8 percentage points below the measured number; measured number inside the range.
By their numbers in this assay, from the lowest: compounds 1, 2, 3 and 4 (each within the scatter of the next, the first and the last beyond it).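

Moving the methoxy group from 2-methoxyphenyl to 4-methoxyphenyl, with the same atoms joined differently, gives in this assay a number 8 percentage points higher from compound 3 to compound 4 (within the scatter) and so does not show that its place on the phenyl ring matters. Even so, this aromatic carbon now gives its first steps beyond the scatter, since 4-methoxyphenyl in place of pyridin-2-yl gives a number 13 percentage points higher from compound 2 to compound 4 (beyond the scatter) and 4-methoxyphenyl in place of tert-butyl gives a number 13 percentage points higher from compound 1 to compound 4 (beyond the scatter) and both of these steps are modest. Nothing measured here accounts for these differences.

From the compounds shown here alone, whether a larger rise in inhibition can be reached at this carbon remains open, for instance with an amine or a carboxylic acid in place of the methoxy group of 4-methoxyphenyl, or with a longer chain on its oxygen. With readings at a single concentration, the potency of these compounds also remains unknown.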